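Trading trifluoromethyl for hydrogen on compound 2

The source may hold more compounds than are shown below. What is called first, only, known or untested is meant among the compounds shown, and "the series" means these compounds.

Two compounds have been measured so far in an ADME assay on MDCK cells (Canis lupus familiaris) for cytotoxicity (on this read-out higher numbers stand for lower toxicity in this test and lower numbers for higher toxicity in this test), and give these values:
Compound 1 `O=[N+]([O-])C1=CNc2nc(-c3ccco3)nn2C1` gives 108000 nM
Compound 2 `O=[N+]([O-])C1=CNc2nc(C(F)(F)F)nn2C1c1c(O)cc(O)cc1O` gives 838000 nM

Compound 2 holds the highest of the two numbers. Compound 1 is its nearest neighbour, and the gap between them lies beyond the usual scatter.

Compound 3 `O=[N+]([O-])C1=CNc2ncnn2C1c1c(O)cc(O)cc1O` has not yet been measured. It carries hydrogen in place of trifluoromethyl on an aromatic carbon. Within the data shown here, no measured pair shows this change alone, and compound 1 and compound 2 differ in more than one place, so the data give no direct guide to its size.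

The expectation therefore rests on compound 2 at 838000 nM in this read-out: no step beyond the scatter. Among the measured compounds shown here, compound 1 at 108000 nM is the only other number, and it tilts the expectation slightly downward. The estimated move is a 1.4-fold lower number from compound 2 to compound 3 (0.15 log units; within the scatter) and stays within the scatter. The estimated value for compound 3 is 600000 nM (expected range 220000 nM to 1500000 nM).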

Compound 3, half-maximal cytotoxic concentration: > 1030000 nM
Compound 3 ended at the assay's limit; the forecaster's own chance of this, stated with the estimate: 10%; middle value at least 1.7-fold (0.23 log units) away from the limit.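

In this assay, among these compounds, the swap of trifluoromethyl for hydrogen on the aromatic carbon between two ring nitrogen atoms can now be read on its own for the first time, and it gives an at least 1.2-fold higher number from compound 2 to compound 3 (0.08 log units; that floor lies within the scatter). Compound 3 gives > 1030000 nM, which is a limit of the assay and not a number, so only a floor for the step is known: the limit of > 1030000 nM in this assay, at which 1 of the 3 values shown sits. The step therefore shows that trifluoromethyl is not required at this position for the low toxicity in this test seen with compound 2, as the compound with plain hydrogen there reaches the top of the range that this assay can report.

From the compounds shown here alone, how far compound 3 actually lies from compound 2 stays open, and so does whether an amine or a carboxylic acid on the same aromatic carbon would also reach this limit. Compound 1 differs from compound 2 in more than one place, so the compounds shown do not tell whether this swap would give a similar step on the core of compound 1.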